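From 3-Fluoro-4-methylphenyl to 4-Chlorophenyl in a Cytotoxicity Test

A few compounds are considered here, and "the series" means these few. Any claim that something is new, unique, unknown or untested is made for them only; others in the source may bear on it.

In a toxicity assay on TZM cells (Homo sapiens) for cytotoxicity, read by XTT assay, with a stated time of 3 days (a lower number here means that less compound is tolerated, a higher number that more compound is tolerated), compound 2 `Cc1ccc(-c2ccc(C(=O)N[C@H](c3nc(C)c(CCO)s3)[C@@H]3CCCCN3)[nH]2)cc1F` gives 28800 nM. Two close relatives lie within the scatter of that number: compound 1 `Cc1ccc(-c2ccc(C(=O)N[C@H](c3nc(C)c(CO)s3)[C@@H]3CCCCN3)[nH]2)cc1F` gives 18000 nM, and compound 3 `Cc1ccc(-c2ccc(C(=O)N[C@@H](c3nc(C)c(CCO)s3)[C@@H]3CCCCN3)[nH]2)cc1F` gives 15300 nM. Compound 2 therefore stands level with both rather than apart from them.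

Compound 4 `Cc1nc([C@@H](NC(=O)c2ccc(-c3ccc(Cl)cc3)[nH]2)[C@@H]2CCCCN2)sc1CCO` has not yet been measured. It carries 4-chlorophenyl in place of 3-fluoro-4-methylphenyl on an aromatic carbon, and the count of that change is 4-chlorophenyl in place of 3-fluoro-4-methylphenyl on an aromatic carbon.

Two measured steps offer some guidance, though neither touches this phenyl group. Hydroxymethyl in place of hydroxy on the chain gave a 1.6-fold higher number from compound 1 to compound 2 (0.20 log units; within the scatter), which is within the scatter. The other step, a 1.9-fold lower number from compound 2 to compound 3 (0.27 log units; within the scatter), is also within the scatter and rests on (the fact that compounds 2 and 3 differ only in the configuration as drawn). Within the data shown here, these steps show only that the number held steady across these three compounds, and no measurement yet tests a change to the phenyl group itself. On that limited basis, no step beyond the scatter is expected in this assay, and no firm direction can be given. The expected change is a 1.3-fold lower number from compound 2 to compound 4 (0.12 log units; within the scatter). For compound 4 the estimated value is 22000 nM, with an expected range from 10000 nM to 48000 nM.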

Compound 4, half-maximal cytotoxic concentration: 17300 nM
The estimate for compound 4 lay 1.3-fold (0.10 log units) above the measured number; the range from low to high includes it.
By their numbers in this assay, from the lowest: compounds 3, 4, 1 and 2 (each within the scatter of the next).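

Among the compounds shown, this is the only step at the phenyl group, the one on an aromatic carbon of the five-membered aromatic ring, next to the ring nitrogen. In this assay, 4-chlorophenyl in place of 3-fluoro-4-methylphenyl gives a 1.7-fold lower number from compound 2 to compound 4 (0.22 log units; within the scatter), so the earlier finding of a steady number now extends from the hydroxyl-bearing chain and the drawn configuration to this aryl group, for this one pair. No measurement shown here explains this result or links it to any property of the two groups.

The swap removes the fluorine and the methyl and adds the chlorine in a single step, so the compounds shown cannot separate what each of these contributes to the number. On these data alone, it also remains open whether the number would stay within the scatter of compound 2 with a different kind of group at this place, such as a phenyl ring carrying an amine or a carboxylic acid, or a saturated ring such as cyclohexyl in place of the aromatic one.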